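A few compounds are considered here, and "the series" means these few. Any claim that something is new, unique, unknown or untested is made for them only; others in the source may bear on it.

Of the compounds shown here, two have been measured so far. Compound 1 `CCOC(=O)C1CCCN(Cc2cn(C3CCCCC3OC(=O)COc3ccccc3)nn2)C1` and compound 2 `CCOC(=O)C1CCCN(Cc2cn(CC(O)COC(=O)c3ccccc3)nn2)C1` were both tested in an assay on nucleic acid for inhibition of Nucleic Acid, read by fluorescence, tested at 100 uM; on this read-out higher numbers stand for more inhibition at the one concentration tested (going by the name of the read-out) and lower numbers for less inhibition. In this assay compound 1 gives 21%. In this assay compound 2 gives 6%, the lowest of the two numbers; its nearest neighbour is compound 1, whose number is higher by a gap that lies beyond the usual scatter. For the measured compounds named here, no single-point step between these two compounds has been recorded, so only their two values speak.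

Compound 3 `CCCCC(O)Cn1cc(CN2CCCC(C(=O)OCC)C2)nn1` has not been measured yet. It differs from compound 2 in one place: propyl in place of benzoyloxy on a saturated chain carbon, two bonds along the chain from an oxygen on a saturated carbon. Compound 2 already sits at the bottom of the measured numbers, and nothing in this assay indicates that swapping benzoyloxy for propyl would lift the read-out; the expectation is therefore a step of no size beyond the scatter in this assay. Compound 3 is expected to give about 8%, with a likely range from 0% to 20%. The implied change, a number 2 percentage points higher from compound 2 to compound 3 (within the scatter), is estimated to stay within the usual scatter.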

Compound 3, a percentage reported as inhibition, at one concentration (the size of the read-out at that concentration, not a potency): 53%
For compound 3 the middle estimate is 45 percentage points below the measured one; measured number above the stated range.
By their numbers in this assay, from the lowest: compound 2; then compound 1; then compound 3.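

In this assay, for the compounds shown here, the saturated chain carbon two bonds along the chain from an oxygen on a saturated carbon turns out to be a place where the read-out responds strongly: propyl in place of benzoyloxy gives a number 47 percentage points higher from compound 2 to compound 3 (beyond the scatter), a large step and the first single-place comparison. It also shows that benzoyloxy, with its six-membered aromatic ring of carbon only and its 9 heavy atoms, is not required for inhibition at the one concentration tested, since compound 3 carries only the 3 carbon atoms of propyl at this place and has no ring there. Nothing shown accounts for why the number moves in this direction or by this much.

The step swaps the whole group at once, so the compounds shown do not separate the loss of the aromatic ring from the loss of the ester oxygens or from the change in chain length. From the compounds shown here alone, how a longer chain such as hexyl, a plain phenyl ring, an amine or a carboxylic acid would read at this place remains open, as does whether the same change would give a step of similar size on a different core.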